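A few compounds are considered here, and "the series" means these few. Any claim that something is new, unique, unknown or untested is made for them only; others in the source may bear on it.

Compound 1 `CC(=O)O[C@@H]1OC(=O)[C@](C)(C(C)=O)[C@@H]1C` gives 5000 nM in a functional assay on HT-29 cells (Homo sapiens) for cytotoxicity, read by MTT assay (on this read-out lower numbers stand for stronger inhibition and higher numbers for weaker inhibition), and compound 3 `CC(=O)[C@]1(C)C(=O)O[C@@H](OC(=O)C(C)(C)C)[C@H]1C` gives 9000 nM in this assay. Compound 2 `CC(=O)O[C@@H]1OC(=O)[C@](C)(C(C)=O)[C@@H]1C(C)C` is known in this assay only as a limit, > 50000 nM, and not as a number. Its value is the single one that sits at the limit of > 50000 nM in this assay, at which 1 of the 3 values shown sits. The step of an at least 10-fold higher number from compound 1 to compound 2 (1.00 log units; beyond the scatter) shows that isopropyl in place of methyl on a saturated ring carbon pushed the read-out out of the measurable range.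

Compound 4 `CC(=O)O[C@@H]1OC(=O)[C@@](C)(C(C)=O)[C@@H]1C(C)C` keeps every atom and bond of compound 2 and differs only in configuration: the two compounds have the same atoms and bonds and differ only in configuration as drawn: 1 of 3 stereo elements differ; a stereocentre at a saturated ring carbon is drawn S in compound 2 and R in compound 4. Among the compounds with values here, no measured step concerns a change of configuration; the one measured step, an at least 10-fold higher number from compound 1 to compound 2 (1.00 log units; beyond the scatter), concerns an exchange of groups. With compound 2 resting at a limit, neither the direction nor the size of the change in this assay can be read from the data, and a wide allowance is the only honest one. Compound 4 is therefore estimated at 50000 nM, with a range from 12000 nM to 200000 nM, which corresponds to an expected step of a number no higher from compound 2 to compound 4 (the limit leaves the size open).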

Compound 4, half-maximal inhibitory concentration: > 50000 nM
Compound 4: only a limit was reported; the forecaster's own chance of this, stated with the estimate: 55%; the middle value lies on the limit itself.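

Compound 2 and compound 4 both rest at a limit in this assay, not at a number, so no new step can be read between them: the limit of > 50000 nM in this assay, at which 2 of the 4 values shown sit.

The compounds shown leave open whether the configuration at that saturated ring carbon has any bearing on the read-out in this assay.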